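Sulfonamide benzoxazoles: a thiophene-to-tolyl swap at the limit

The source may report more compounds than this note shows. Statements on the series, on what has been measured and on what is new or still open speak of the compounds shown alone.

Compound 1 `O=S(=O)(Nc1ccc(-c2nc3ccccc3o2)cc1)c1cccs1`: in an assay on isolated protein for inhibition of malate dehydrogenase, mitochondrial (Sus scrofa), with stated times of 45 min and 30 min (a higher number here means a weaker inhibitor, a lower number a stronger inhibitor), compound 1 gives > 63000 nM, which is a limit of the assay and not a number.
Compound 2 `O=S(=O)(Nc1ccc2oc(-c3ccccc3)nc2c1)c1cccc(O)c1`: in this assay compound 2 gives > 63000 nM, again a limit of the assay.
Compound 3 `O=S(=O)(Nc1ccc2oc(-c3ccccc3)nc2c1)c1ccc(Cl)c(Cl)c1`: in this assay compound 3 gives > 63000 nM, also a limit of the assay.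

Among the measured compounds shown here, compound 1 therefore stands at the same limit as every other measured member; the limit of > 63000 nM in this assay, at which 3 of the 3 values shown sit, is the only evidence the set holds. For the measured compounds named here, the one step between measured compounds, a step that the two limits leave unreadable from compound 2 to compound 3, runs between two limits and its size cannot be read, so it gives no guide to how a change on the sulfonyl sulfur moves the value.

Compound 4 `Cc1cccc(S(=O)(=O)Nc2ccc(-c3nc4ccccc4o3)cc2)c1` differs from compound 1 in that (3-methylphenyl in place of thiophen-2-yl on a sulfonyl sulfur). No measured step bears on this change, and no measured compound has yet shown a number rather than a limit. Compound 4 is therefore expected to remain at or beyond the same limit, an estimated step that the limit leaves unreadable from compound 1 to compound 4. The estimate for compound 4 in this assay is 90000 nM, within 30000 nM to 300000 nM.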

Compound 4, half-maximal inhibitory concentration: > 63000 nM
Compound 4: only a limit was reported; the forecaster's own chance of this, stated with the estimate: 85%; the middle value lies beyond the limit too.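

In this assay compound 4 gives > 63000 nM, a limit of the assay and not a number. Compound 1 also stands at a limit, so the step between compound 1 and compound 4 cannot be read. The compounds shown leave open whether any group on a sulfonyl sulfur gives a readable value, the only evidence being: the limit of > 63000 nM in this assay, at which 4 of the 4 values shown sit.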